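Thiourea-type side chain in place of cyanoguanidine-type group

The source may hold more compounds than are shown below. What is called first, only, known or untested is meant among the compounds shown, and "the series" means these compounds.

Working notes on a small series tested in a functional assay on the whole organism (stomach) with Rattus norvegicus as the target; on this read-out higher numbers stand for an effect only at larger amounts of compound and lower numbers for an effect already at smaller amounts. Going by the values given here, compound 1, `CN(C)/C(=N/CCCCn1nc(-c2ccccc2)ccc1=O)NC#N`, is the only member with a number: in this assay compound 1 gives 30.3 mg/kg. Compound 2, `O=c1ccc(-c2ccccc2)nn1CCCC/N=C(\S)Nc1cccc(F)c1`, reaches no number; in this assay compound 2 gives only the limit > 100 mg/kg. Compound 3, `C/N=C(/NC#N)NCCCCCn1nc(-c2ccccc2)cc(C)c1=O`, likewise; in this assay compound 3 gives only the limit > 100 mg/kg. Among the compounds with values here, compound 1 thus stands as the single measured dose, with the limit of > 100 mg/kg in this assay, at which 2 of the 3 values shown sit, for the rest of the set, and no pair of measured compounds differs in one place, so no measured step is available to calibrate any change.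

Compound 4, `CC/N=C(\S)NCCCCn1nc(-c2ccccc2)ccc1=O`, is not yet measured. It differs from compound 1 by a group of 6 heavy atoms (3 carbon, 2 nitrogen, 1 sulfur; no ring) in place of a group of 8 heavy atoms (4 carbon, 4 nitrogen; no ring), on a saturated chain carbon, four bonds along the chain from an aromatic nitrogen.

Without a measured step of this kind, the expectation rests on compound 1 at 30.3 mg/kg and on what compound 2 and compound 3 show. Compound 4 is expected to need a larger dose than compound 1, with a real chance of reaching only a limit. The expected step is a 2.1-fold higher number from compound 1 to compound 4 (0.33 log units; beyond the scatter), a loss beyond the scatter. Compound 4 is estimated at 65 mg/kg, with a range from 25 mg/kg to 160 mg/kg.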

Compound 4, dose for half-maximal effect: 37.2 mg/kg
Compound 4: middle estimate off by 1.7-fold (0.24 log units), on the high side; measured number inside the range.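

In this assay, going by these compounds alone, the exchange of the cyanoguanidine-type group for a thiourea-type side chain, on a saturated chain carbon, four bonds along the chain from an aromatic nitrogen, provides the first measured step: a 1.2-fold higher number from compound 1 to compound 4 (0.09 log units; within the scatter). On the core of compound 1, this position therefore accepts the group of 6 heavy atoms in place of the group of 8 heavy atoms with no change that can be told from the scatter, so the cyanoguanidine-type group is not required for a measurable dose here. A thiourea-type side chain alone also does not place a compound at the limit, as compound 4 gives a number and stays outside the limit values of the set: the limit of > 100 mg/kg in this assay, at which 2 of the 4 values shown sit.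

The compounds shown leave open what sets compound 2 and compound 3 apart from compound 4, as no step to either limit compound can be read. Also open, from the compounds shown here alone, is how a urea, with oxygen in place of sulfur, or a propyl or butyl group in place of the ethyl group of compound 4 would stand in this assay.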